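The compounds below may be only part of what the source reports. "The series", "measured", "known", "first", "only" and "open" are said of these compounds alone.

Compounds measured in an ADME assay on Vero cells (Chlorocebus sabaeus) for cytotoxicity, read by MTT assay, with a stated time of 72 h; a higher number here means that more compound is tolerated, a lower number that less compound is tolerated:
- Compound 1, `CC(=O)N1CCN(c2nc(=O)c3cc(C(F)(F)F)cc([N+](=O)[O-])c3s2)CC1`, gives > 125000 nM; this is a limit of the assay, not a number.
- Compound 2, `O=C(C1CCCCC1)N1CCN(c2nc(=O)c3cc(C(F)(F)F)cc([N+](=O)[O-])c3s2)CC1`, gives 88700 nM.
- Compound 3, `O=C(c1cccc(F)c1)N1CCN(c2nc(=O)c3cc(C(F)(F)F)cc([N+](=O)[O-])c3s2)CC1`, gives > 125000 nM; this too is a limit, not a number.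

Compound 3 thus stands at the limit of > 125000 nM in this assay, at which 2 of the 3 values shown sit. Compound 4, `O=C(c1ccc(F)cc1)N1CCN(c2nc(=O)c3cc(C(F)(F)F)cc([N+](=O)[O-])c3s2)CC1`, differs from it by 4-fluorophenyl in place of 3-fluorophenyl on a carbonyl carbon. The steps bearing on the acyl group are an at least 1.4-fold higher number from compound 2 to compound 3 (0.14 log units; that floor lies within the scatter) and a step that the two limits leave unreadable from compound 1 to compound 3, both ending at the limit. On this basis no step beyond the scatter is expected, an at least 1.0-fold lower number from compound 3 to compound 4 (0.01 log units; that floor lies within the scatter). Compound 4 is therefore expected to give about 120000 nM in this assay, within the range from 60000 nM to 250000 nM.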

Compound 4, half-maximal cytotoxic concentration: > 125000 nM
Compound 4: a limit, no number; the forecaster's own chance of this, stated with the estimate: 65%; at least 1.0-fold (0.01 log units) between middle value and limit.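

In this assay compound 4 gives a limit, not a number, so 4-fluorophenyl on this carbonyl carbon leaves the compound where 3-fluorophenyl left it: the limit of > 125000 nM in this assay, at which 3 of the 4 values shown sit. The steps to compound 4 from compound 3 and from compound 1 cannot be read, with limits at both ends. Going by these compounds alone, the one step that can be read is an at least 1.4-fold higher number from compound 2 to compound 4 (0.14 log units; that floor lies within the scatter). Going by these compounds, how far the compounds at this limit differ from one another stays open. So does whether an amine, a carboxylic acid or a longer chain in this acyl group would give a number.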